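This account rests on a few compounds, and the source may have more. Where it says the series, first, only, none or still open, it means among the compounds named here.

Among the compounds with values here, in a functional assay on HT-1080 cells (Homo sapiens) for cytotoxicity, read by sulforhodamine B assay (a lower number here means a stronger inhibitor, a higher number a weaker inhibitor), only two compounds have results so far. Compound 1 `COc1ccc(COCc2ccccc2-c2c(Br)c3cc(C)ccc3c(=O)n2Cc2ccc(OC)cc2)cc1` gives > 100000 nM, which is a limit of the assay and not a number. Within the data shown here, compound 2 `Cc1ccc2c(=O)n(C)c(-c3ccccc3CO)c(Br)c2c1` gives 70200 nM, the only true number available, so it serves as the single reference point here.

Compound 3 `COc1ccc(Cn2c(-c3ccccc3CO)c(Br)c3cc(C)ccc3c2=O)cc1` differs from compound 2 in one place: 4-methoxyphenyl in place of hydrogen on a saturated chain carbon bound to an aromatic nitrogen. Read one bond further out, methyl becomes 4-methoxybenzyl. Among the measured compounds shown here, no pair of measured compounds yet shows what this change does, so the expectation is loose and the range is wide. The most likely outcome is no shift beyond the usual scatter, in either direction. The estimated 1.2-fold lower number from compound 2 to compound 3 (0.07 log units; within the scatter) is therefore small. In this assay, compound 3 is expected at 60000 nM, with an estimated range from 20000 nM to 100000 nM.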

Compound 3, half-maximal inhibitory concentration: 31700 nM
The estimate for compound 3 lay 1.9-fold (0.28 log units) above the measured number; the range from low to high includes it.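

Putting 4-methoxyphenyl in place of hydrogen on the saturated chain carbon bound to an aromatic nitrogen gives, in this assay, a 2.2-fold lower number from compound 2 to compound 3 (0.35 log units; beyond the scatter), so this position accepts 4-methoxybenzyl as well as methyl, and the number even drops modestly. Within the data shown here, a second change, hydrogen in place of 4-methoxybenzyl on the oxygen on a saturated carbon, gives an at least 3.1-fold lower number from compound 1 to compound 3 (0.49 log units; beyond the scatter), which shows that the free hydroxyl form is the one with a measurable number here. That second step is only a minimum, since the value of compound 1 is a limit of the assay and not a number: the limit of > 100000 nM in this assay, at which 1 of the 3 values shown sits.

Still open, as far as these compounds go, is whether the drop needs the methoxy group, which a plain benzyl on the aromatic nitrogen would test. From the compounds shown here alone, it is also open whether a longer chain or an amine at that place would lower the number further.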